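Changing the Fluorinated Ring on the Double-Bonded Chain

The source may hold more compounds than are shown below. What is called first, only, known or untested is meant among the compounds shown, and "the series" means these compounds.

Two compounds have been measured in a functional assay on ME-180 cells (Homo sapiens) for cytotoxicity, read by MTT assay, with a stated time of 72 h; a lower number here means a stronger inhibitor, a higher number a weaker inhibitor:

Compound 1, `COc1ccc(C(=O)c2cc(OC)c(OC)c(OC)c2)cc1NC(=O)/C=C/c1ccc(OC)c(OC)c1`, gives 8900 nM.
Compound 2, `COc1ccc(C(=O)c2cc(OC)c(OC)c(OC)c2)cc1NC(=O)/C=C/c1ccc(C(F)(F)F)cc1`, gives 800 nM.

Going by the values given here, compound 2 has the lower of the two numbers, and the only step measured so far runs an 11-fold lower number from compound 1 to compound 2 (1.05 log units; beyond the scatter), a large change produced by swapping the 3,4-dimethoxyphenyl for a 4-(trifluoromethyl)phenyl on the double-bonded chain carbon.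

Among the compounds with values here, compound 3, `COc1ccc(C(=O)c2cc(OC)c(OC)c(OC)c2)cc1NC(=O)/C=C/c1cccc(OC(F)(F)F)c1`, keeps the shared core and alters only that same ring: 3-(trifluoromethoxy)phenyl in place of 4-(trifluoromethyl)phenyl on a double-bonded chain carbon bound to a double-bonded chain carbon. Within the data shown here, both rings carry a three-fluorine group, so the new change is far smaller in kind than the one from compound 1 to compound 2. Among the measured compounds shown here, no measured step trades trifluoromethyl for trifluoromethoxy, and none shifts a substituent to a different ring position, so the earlier step says little about direction here. The expectation is therefore a modest move, if any, with a slight lean toward a weaker compound, as a 1.9-fold higher number from compound 2 to compound 3 (0.27 log units; within the scatter) expresses. Compound 3 is estimated at 1500 nM, within a range of 400 nM to 6000 nM.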

Compound 3, half-maximal inhibitory concentration: 9200 nM
Compound 3: the middle estimate sits 6.1-fold (0.79 log units) below what was measured, and the stated range ends below it.
By their numbers in this assay, from the lowest: compound 2; then compounds 1 and 3 (each within the scatter of the next).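

In this assay, this position proves sensitive even to a change between two rings that each carry a three-fluorine group: putting 3-(trifluoromethoxy)phenyl in place of 4-(trifluoromethyl)phenyl gives a 12-fold higher number from compound 2 to compound 3 (1.06 log units; beyond the scatter) and removes the whole advantage of the earlier step. Fluorine on this ring is therefore not enough on its own to give a low number, for the 3-(trifluoromethoxy)phenyl and 3,4-dimethoxyphenyl rings cannot be told apart, with a 1.0-fold higher number from compound 1 to compound 3 (0.01 log units; within the scatter) and so, among these three compounds, only the 4-(trifluoromethyl)phenyl ring of compound 2 stands out. Nothing available explains why these two fluorinated rings behave so differently.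

The swap alters two things at once, the group itself and the number in its name that gives its place on the ring, so the compounds shown cannot say which of the two accounts for the large step. A 3-(trifluoromethyl)phenyl or a 4-(trifluoromethoxy)phenyl ring would pull these two apart, while a ring bearing an amine or a carboxylic acid would show whether anything other than fluorinated groups can be tolerated here.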